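Series notes: from compound 3 to a substituted benzyl analogue

A few compounds are considered here, and "the series" means these few. Any claim that something is new, unique, unknown or untested is made for them only; others in the source may bear on it.

Measured compounds in a functional assay on CHO cells for antagonist activity at prostaglandin E2 receptor EP4 subtype (Homo sapiens), read by calcium flux, with a stated time of 15 min; a higher number here means a weaker inhibitor, a lower number a stronger inhibitor:
Compound 1 `C[C@H](NC(=O)c1nnn(Cc2ccc(C(F)(F)F)cc2)c1C(F)(F)F)c1ccc(C(=O)O)cc1` gives > 10000 nM, which is a limit of the assay.
Compound 2 `Cc1c(C(=O)N[C@@H](C)c2ccc(C(=O)O)cc2)nnn1Cc1ccc(C(F)(F)F)cc1` gives > 10000 nM, again a limit of the assay.
Compound 3 `C[C@H](NC(=O)c1c(-c2ccccc2)nnn1Cc1ccccc1)c1ccc(C(=O)O)cc1` gives 647 nM.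

Among the compounds with values here, compound 3 therefore holds the only number in this assay; the other two values sit at the limit of > 10000 nM in this assay, at which 2 of the 3 values shown sit. Within the data shown here, the single step between measured compounds, a step that the two limits leave unreadable from compound 1 to compound 2, lies between two limits and its size cannot be read. It also concerns a different place than the change considered here.

Compound 4 `COc1ccc(Cn2nnc(-c3ccccc3)c2C(=O)N[C@@H](C)c2ccc(C(=O)O)cc2)cc1F` differs from compound 3 by 3-fluoro-4-methoxyphenyl in place of phenyl on a saturated chain carbon bound to an aromatic nitrogen. Among the measured compounds shown here, no measured step bears on this change: the only one available is unreadable and sits elsewhere in the molecule. With nothing to read, no step beyond the usual scatter is expected in this assay; the estimated step is a 1.2-fold lower number from compound 3 to compound 4 (0.07 log units; within the scatter). Compound 4 is thus expected near 550 nM, with a range from 150 nM to 2500 nM, the width reflecting the absence of any guiding step.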

Compound 4, half-maximal inhibitory concentration: 29.8 nM
Beside the measured number, compound 4's estimate is 18-fold (1.27 log units) above it, outside the stated range (below it).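

In this assay, replacing benzyl with 3-fluoro-4-methoxybenzyl gives a 22-fold lower number from compound 3 to compound 4 (1.34 log units; beyond the scatter), which shows that the position on a saturated chain carbon bound to an aromatic nitrogen accepts this larger group and responds strongly to the change. Within the data shown here, the earlier compounds could not show this: compound 1 and compound 2 each differ from compound 3 in more than one place, and the only step among them, which runs between two assay limits, cannot be read. Nothing at hand accounts for the size of this step.

From the compounds shown here alone, the 3-fluoro and 4-methoxy parts enter together, so their separate shares in the step stay open. A benzyl carrying only one of them, or a nitrile or an amine at this position, lies outside the compounds shown.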